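The source may report more compounds than this note shows. Statements on the series, on what has been measured and on what is new or still open speak of the compounds shown alone.

Compound 1 `O=Cc1ccc(OCc2cn(-c3ccc(S(=O)(=O)N4CCc5ccccc5C4)cc3)nn2)cc1` is measured in an ADME assay on Vero cells (Chlorocebus sabaeus) for cytotoxicity, with a stated time of 4 days; a higher number here means a weaker inhibitor, a lower number a stronger inhibitor. In this assay compound 1 gives only the limit of > 50 ug/mL, so no number stands for it. Compound 2 `COc1cc2c(cc1OC)CN(S(=O)(=O)c1ccc(-n3cc(COc4ccc(C)cc4)nn3)cc1)CC2` also reaches only the limit of > 50 ug/mL. Compound 3 `COc1cc2c(cc1OC)CN(S(=O)(=O)c1ccc(-n3cc(CO)nn3)cc1)CC2` likewise gives only the limit of > 50 ug/mL. The step that the two limits leave unreadable from compound 2 to compound 3 cannot be sized because of the limit of > 50 ug/mL in this assay, at which 3 of the 3 values shown sit. Compound 4 `O=S(=O)(c1ccc(-n2cc(CO)nn2)cc1)N1CCc2ccccc2C1` differs from compound 1 by hydrogen in place of 4-formylphenyl on an oxygen on a saturated carbon. Within the data shown here, the only measured step of the same kind is a step that the two limits leave unreadable from compound 2 to compound 3, and it shows no readable movement. Compound 4 is therefore expected to stay at the limit as well, estimated at 60 ug/mL with a range from 30 ug/mL to 150 ug/mL. The expected step that the limit leaves unreadable from compound 1 to compound 4 is none beyond the scatter.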

Compound 4, half-maximal inhibitory concentration: > 50 ug/mL
Compound 4 gave a limit, no number; the forecaster's own chance of this, stated with the estimate: 85%; the middle value is on the limit's open side.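

No new step can be read between compound 1 and compound 4, since each gives only a limit and no number: the limit of > 50 ug/mL in this assay, at which 4 of the 4 values shown sit.

In this assay the compounds shown leave open where any of their true values lies beyond that limit.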